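A few compounds are considered here, and "the series" means these few. Any claim that something is new, unique, unknown or untested is made for them only; others in the source may bear on it.

Measured in an ADME assay on Vero cells (Chlorocebus sabaeus) for cytotoxicity, read by MTT assay, with a stated time of 72 h; on this read-out lower numbers stand for stronger inhibition and higher numbers for weaker inhibition:
- compound 1 `CC1CN(c2nc3c(cc2[N+](=O)[O-])c(=O)c(C(=O)O)cn3C2CC2)CC(C)O1`: > 160000 nM (a limit)
- compound 2 `O=C(O)c1cn(C2CC2)c2nc(N3CCC4(CC3)OCCO4)c([N+](=O)[O-])cc2c1=O`: 150000 nM

Compound 1 is known only through a limit: the limit of > 160000 nM in this assay, at which 1 of the 2 values shown sits. Compound 3 `CC1CN(c2nc3c(cc2[N+](=O)[O-])c(=O)c(C(=O)O)cn3-c2ccc(F)cc2)CC(C)O1` has not yet been measured in this assay. It keeps the core of compound 1 and carries one change, 4-fluorophenyl in place of cyclopropyl on an aromatic nitrogen.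

Among the measured compounds shown here, only one measured step is available, an at least 1.0-fold lower number from compound 1 to compound 2 (0.02 log units; that floor lies within the scatter). For the measured compounds named here, it bears on this change only loosely, since it concerns a group on an aromatic carbon, and no measured step alters the group on the aromatic nitrogen. With compound 2 at 150000 nM, both readings lie high on the scale. A modest move towards a lower number is therefore expected in this assay, though it may not exceed the scatter, and another reading at a limit would be no surprise. The change is expected to amount to an at least 1.4-fold lower number from compound 1 to compound 3 (0.16 log units; that floor lies within the scatter). For compound 3 the estimated value is 110000 nM, with an expected range of 40000 nM to 170000 nM.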

Compound 3, half-maximal inhibitory concentration: 141000 nM
Compound 3: middle estimate off by 1.3-fold (0.11 log units), on the low side; measured number inside the range.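

In this assay, among the compounds shown here, the first reading at this position, on an aromatic nitrogen of the shared core, comes from 4-fluorophenyl in place of cyclopropyl, and it amounts to an at least 1.1-fold lower number from compound 1 to compound 3 (0.05 log units; that floor lies within the scatter). The larger aromatic group thus leaves compound 3 at a measured 141000 nM, still high on the scale, and the data show no clear move beyond the scatter for this change. The true size of the step stays unknown because compound 1 is known only through a limit: the limit of > 160000 nM in this assay, at which 1 of the 3 values shown sits.

What the compounds shown leave open is whether other groups on the same aromatic nitrogen, such as a plain phenyl or an ethyl, would give a different reading in this assay, and whether the reading of compound 3 depends on the fluorine of its 4-fluorophenyl group. As far as these compounds go, it also remains open how the shared core would read with an amine in place of the nitro group, or with an ester in place of the carboxylic acid.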